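A few compounds are considered here, and "the series" means these few. Any claim that something is new, unique, unknown or untested is made for them only; others in the source may bear on it.

In a functional assay on HCT-116 cells (Homo sapiens) for inhibition, read by MTT assay, with a stated time of 72 h (on this read-out higher numbers stand for weaker inhibition and lower numbers for stronger inhibition), compound 1 (`CC(C)CCN(CCCCCCC(=O)NO)c1ncc(C(=O)NCc2cccnc2)s1`) gives 12000 nM and compound 2 (`CC(C)CCN(CCCCCC(=O)NO)c1ncc(C(=O)NCCCn2ccnc2)s1`) gives 85000 nM. Compound 2 therefore holds the higher of the two numbers, meaning the weaker inhibition, and its gap to compound 1 lies beyond the scatter. Compound 3 (`CC(C)CCN(CCCCCCC(=O)NO)c1ncc(C(=O)NCCCn2ccnc2)s1`) arises from compound 2 through a single change: (hydroxycarbamoyl)methyl in place of hydroxycarbamoyl on a saturated chain carbon, five bonds along the chain from a nitrogen on an aromatic ring. Going by the values given here, no measured pair isolates this change, so any expectation is tentative. A moderate shift toward stronger inhibition in this assay is expected, though a result within the scatter would be unsurprising. Among the compounds with values here, the only lower number available is that of compound 1, at 12000 nM, which serves as a rough guide. The expected step is a 3.4-fold lower number from compound 2 to compound 3 (0.53 log units; beyond the scatter). For compound 3, the estimated value is 25000 nM, with an expected range of 8000 nM to 70000 nM.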

Compound 3, half-maximal inhibitory concentration: 30000 nM
For compound 3 the middle estimate is 1.2-fold (0.08 log units) below the measured one; measured number inside the range.
By their numbers in this assay, from the lowest: compound 1; then compound 3; then compound 2.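

In this assay, (hydroxycarbamoyl)methyl in place of hydroxycarbamoyl on a saturated chain carbon, five bonds along the chain from a nitrogen on an aromatic ring, gives a 2.8-fold lower number from compound 2 to compound 3 (0.45 log units; beyond the scatter): a modest step, now read for this change alone. At the other end of the molecule, 2-(1H-imidazol-1-yl)ethyl in place of pyridin-3-yl on a saturated chain carbon bound to an amide-type nitrogen gives a 2.5-fold higher number from compound 1 to compound 3 (0.40 log units; beyond the scatter), so the gap between compound 1 and compound 2 now resolves into two separate modest steps. Nothing available bears on the reason for either step.

From the compounds shown here alone, whether the trend continues with a chain one carbon longer than in compound 3 remains open. Also open, going by these compounds, is how a carboxylic acid in place of the hydroxycarbamoyl group would read in this assay.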